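A few compounds are considered here, and "the series" means these few. Any claim that something is new, unique, unknown or untested is made for them only; others in the source may bear on it.

Going by the values given here, compound 2 `Cc1ccc(S(=O)(=O)c2nc3ccccc3nc2Nc2cccc(N)c2)cc1` gives the only actual number in a functional assay on A549 cells (Homo sapiens) for cytotoxicity, read by MTT assay, with a stated time of 72 h (a lower number here means a stronger inhibitor, a higher number a weaker inhibitor), namely 1950 nM. Compound 1 `COc1ccc(Nc2nc3ccccc3nc2S(=O)(=O)c2ccc(C)cc2)cc1` reaches only the assay limit of > 50000 nM. Compound 3 `Cc1ccc(S(=O)(=O)c2nc3ccccc3nc2Nc2ccc(Cl)cc2)cc1` differs from compound 2 in one place: 4-chlorophenyl in place of 3-aminophenyl on a nitrogen on an aromatic ring. Among the compounds with values here, the single measured step at this position, an at least 25-fold lower number from compound 1 to compound 2 (1.40 log units; beyond the scatter), shows that the group on this nitrogen can shift the result a long way; that comparison rests on (the limit of > 50000 nM in this assay, at which 1 of the 2 values shown sits), so its true size is unknown. For the new swap, a step of a 4.1-fold higher number from compound 2 to compound 3 (0.61 log units; beyond the scatter) toward a weaker compound is expected, with wide uncertainty. Compound 3 is therefore estimated at 8000 nM, within 1500 nM to 50000 nM.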

Compound 3, half-maximal inhibitory concentration: 54200 nM
Beside the measured number, compound 3's estimate is 6.8-fold (0.83 log units) below it; the whole stated range lies below it.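

In this assay, putting 4-chlorophenyl in place of 3-aminophenyl gives a 28-fold higher number from compound 2 to compound 3 (1.44 log units; beyond the scatter). Unlike the earlier step, this one joins two actual numbers, so its large size can be read and the strong dependence on the group at this nitrogen no longer rests on a limit alone. The step between compound 1 and compound 3 cannot be read: the limit of > 50000 nM in this assay, at which 1 of the 3 values shown sits.

From the compounds shown here alone, what stays open is whether the amine itself or its place on the ring matters. A 4-aminophenyl or a 3-chlorophenyl group on this nitrogen would help separate the two.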